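Branching the Alkyne Chain on an Adenosine-Derived Amine

This account rests on a few compounds, and the source may have more. Where it says the series, first, only, none or still open, it means among the compounds named here.

Compound 1 `CN(CC[C@H](N)C(=O)O)C[C@H]1O[C@@H](n2cnc3c(N)ncnc32)[C@H](O)[C@@H]1O` is the parent of this small set. In an assay for inhibition of tRNA (cytosine(38)-C(5))-methyltransferase (Homo sapiens), with a stated time of 5 min, tested at 100 uM (on this read-out higher numbers stand for more inhibition at the one concentration tested (going by the name of the read-out) and lower numbers for less inhibition), compound 1 gives 30.3%. Compound 2 `CC#CCN(CC[C@H](N)C(=O)O)C[C@H]1O[C@@H](n2cnc3c(N)ncnc32)[C@H](O)[C@@H]1O` gives 61.3%, and compound 3 `CCC#CCN(CC[C@H](N)C(=O)O)C[C@H]1O[C@@H](n2cnc3c(N)ncnc32)[C@H](O)[C@@H]1O` gives 62.8%. Among these three numbers compound 3 stands highest, though its gap to compound 2 is within the scatter, so the two cannot be ordered; only compound 1 is clearly lower.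

The two large steps both run from the parent: a number 31 percentage points higher from compound 1 to compound 2 (beyond the scatter) and a number 32.5 percentage points higher from compound 1 to compound 3 (beyond the scatter). Adding a methyl to the chain gave a number 1.5 percentage points higher from compound 2 to compound 3 (within the scatter).

Compound 4 `C#CC(C)(C)N(CC[C@H](N)C(=O)O)C[C@H]1O[C@@H](n2cnc3c(N)ncnc32)[C@H](O)[C@@H]1O` keeps the same atoms as compound 3 but joins them differently: 1,1-dimethylprop-2-yn-1-yl in place of pent-2-yn-1-yl on an amine nitrogen. The measured steps show that placing an alkyne-bearing chain on the amine nitrogen raises inhibition strongly and that extending that chain changes little; none of them tests this new arrangement of the same atoms. The alkyne is kept, so most of the gain over compound 1 is expected to persist, with some allowance for the unfamiliar arrangement. Compound 4 is therefore expected to reach about 50%, in a range from 30% to 68%. That estimate would mean a number 12.8 percentage points lower from compound 3 to compound 4 (beyond the scatter).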

Compound 4, a percentage reported as inhibition, at one concentration (the size of the read-out at that concentration, not a potency): 17.3%
Compound 4: the middle estimate sits 32.7 percentage points above what was measured; measured number outside the range, below it.
By their numbers in this assay, from the lowest: compound 4; then compound 1; then compounds 2 and 3 (each within the scatter of the next).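

On an amine nitrogen, the same five carbons and single triple bond can give very different results, as 1,1-dimethylprop-2-yn-1-yl in place of pent-2-yn-1-yl gave a number 45.5 percentage points lower from compound 3 to compound 4 (beyond the scatter) and the same group in place of but-2-yn-1-yl gave a number 44 percentage points lower from compound 2 to compound 4 (beyond the scatter) in this assay. Going by these compounds alone, a triple bond on this nitrogen is therefore not enough to secure the gain seen in the earlier compounds, and this five-carbon group even falls short of the small methyl of the parent, with a number 13 percentage points lower from compound 1 to compound 4 (beyond the scatter) as the step. The measurements shown give no explanation for how the joining of these atoms produces such a drop.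

Compound 4 differs from compound 3 in two ways at once, carrying two methyl groups on the chain carbon bound to the amine nitrogen and having its triple bond elsewhere in the chain, so the compounds shown cannot tell which of these features matters. An unbranched prop-2-yn-1-yl group and a singly branched 1-methylprop-2-yn-1-yl group on the same nitrogen would help pull these two features apart.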